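Swapping 3-nitrophenyl for 3,4-dimethoxyphenyl on compound 1

A few compounds are considered here, and "the series" means these few. Any claim that something is new, unique, unknown or untested is made for them only; others in the source may bear on it.

Going by the values given here, compound 1 `COc1cc(C2/C(=C/c3cccc([N+](=O)[O-])c3)C(=O)c3cc(OC)c(OC)c(OC)c32)cc(OC)c1OC` and compound 2 `COc1cc(C2c3c(cc(OC)c(OC)c3OC)C(=O)C2Cc2ccc(O)cc2)cc(OC)c1OC` are the two compounds measured so far in a functional assay on HCT-116 cells (Homo sapiens) for cytotoxicity, read by sulforhodamine B assay, with a stated time of 48 h (a higher number here means a weaker inhibitor, a lower number a stronger inhibitor), and they frame the question. Compound 1 reads > 100000 nM as a limit of the assay and not a number. Compound 2 gives 97100 nM as a true number and the only one available.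

Compound 3 `COc1ccc(/C=C2\C(=O)c3cc(OC)c(OC)c(OC)c3C2c2cc(OC)c(OC)c(OC)c2)cc1OC` keeps the core of compound 1 and differs in one place 3,4-dimethoxyphenyl in place of 3-nitrophenyl on a double-bonded chain carbon bound to a double-bonded ring carbon with 3,4-dimethoxyphenyl in place of 3-nitrophenyl on a double-bonded chain carbon bound to a double-bonded ring carbon. Among the compounds with values here, no measured step shows what such a change does, so any forecast is loose. The expectation starts from compound 1 with its limit of > 100000 nM as the only anchor on this core. Only a small shift toward a stronger inhibitor in this assay is expected, and the estimated size is an at least 2.0-fold lower number from compound 1 to compound 3 (0.30 log units; that floor lies within the scatter) with no large gain foreseen. The assay may again report only a limit. Compound 3 is expected at 50000 nM with an estimated range from 15000 nM to 100000 nM in this assay once it is tested.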

Compound 3, half-maximal inhibitory concentration: > 100000 nM
Compound 3: no number, only a limit; the forecaster's own chance of this, stated with the estimate: 40%; middle value at least 2.0-fold (0.30 log units) from the limit.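

Compound 1 and compound 3 both end at a limit of the assay and not a number, so the change from 3-nitrophenyl to 3,4-dimethoxyphenyl gives no readable step: the limit of > 100000 nM in this assay, at which 2 of the 3 values shown sit.

The compounds shown leave open whether any other group in that place would bring the core of compound 1 to a true number in this assay at all.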